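The source may report more compounds than this note shows. Statements on the series, on what has been measured and on what is new or still open speak of the compounds shown alone.

Among the measured compounds shown here, compound 2 `O=C(CCCC1CCN(C(=O)CCC2CCCCC2)CC1)c1ncco1` gives 3 nM in an assay on isolated protein for inhibition of Fatty-acid amide hydrolase 1 (Homo sapiens) (a lower number here means a stronger inhibitor, a higher number a weaker inhibitor), the lowest number of the three measured so far: compound 1 `O=C(CCCC1CCN(C(=O)CC2CCCCC2)CC1)c1ncco1` gives 100 nM and compound 3 `O=C(CCCC1CCN(S(=O)(=O)Cc2ccccc2)CC1)c1ncco1` gives 600 nM. For the measured compounds named here, the only step between neighbours differing in one place, a 33-fold lower number from compound 1 to compound 2 (1.52 log units; beyond the scatter), shows how sharply this assay answers to the group on the carbonyl attached to the ring nitrogen. Compound 4 `CC(C)OC(=O)N1CCC(CCCC(=O)c2ncco2)CC1` alters that same position more deeply: isopropoxy in place of 2-cyclohexylethyl on a carbonyl carbon. Going by the values given here, no measured step covers such a group at this carbonyl, so the expectation leans on the size of the step of a 33-fold lower number from compound 1 to compound 2 (1.52 log units; beyond the scatter) and on the high number of compound 3. A clear rise in the number is expected, a 50-fold higher number from compound 2 to compound 4 (1.70 log units; beyond the scatter). Compound 4 is therefore estimated at 150 nM, within 20 nM to 1500 nM.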

Compound 4, half-maximal inhibitory concentration: 4 nM
Compound 4: the middle estimate sits 38-fold (1.57 log units) above what was measured; the measured number lies below the stated range.
By their numbers in this assay, from the lowest: compounds 2 and 4 (each within the scatter of the next); then compound 1; then compound 3.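

In this assay, isopropoxy in place of 2-cyclohexylethyl gives a 1.3-fold higher number from compound 2 to compound 4 (0.12 log units; within the scatter), so a low number at this carbonyl does not require a six-membered non-aromatic ring on the group. Isopropoxy in place of cyclohexylmethyl gives a 25-fold lower number from compound 1 to compound 4 (1.40 log units; beyond the scatter), so across these three groups the number does not follow heavy-atom count in one direction. Nothing available explains this result. The compounds shown leave open whether the oxygen of isopropoxy contributes, which an isobutyl group at this carbonyl would test. Also open, from the compounds shown here alone, is how a cyclohexyloxy or tert-butoxy group would read here.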